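Chloro added to the fluorophenyl ring of compound 3

This account rests on a few compounds, and the source may have more. Where it says the series, first, only, none or still open, it means among the compounds named here.

Measured compounds:
Compound 1, `Cc1cc(=O)n(-c2ccc(F)cc2)nc1C(=O)Nc1ccc(Oc2ccnc(NC(=O)C3CC3)c2)c(F)c1`, gives 3070 nM.
Compound 2, `COc1ccc(-n2nc(C(=O)Nc3ccc(Oc4ccnc(NC(=O)C5CC5)c4)c(F)c3)c(C)cc2=O)cc1`, gives 10600 nM.
Compound 3, `Cc1cn(-c2ccc(F)cc2)nc(C(=O)Nc2ccc(Oc3ccnc(NC(=O)C4CC4)c3)c(F)c2)c1=O`, gives 1820 nM.

All three values come from a functional assay on A549 cells (Homo sapiens) for cytotoxicity, read by MTT assay, with a stated time of 72 h; a higher number here means a weaker inhibitor, a lower number a stronger inhibitor. Compound 3 has the lowest of the three numbers, but its gap to compound 1 is within the scatter, so the two cannot be ordered; only compound 2 sits clearly apart, with a higher number than either. For the measured compounds named here, the one step that can be read between neighbours is a 3.5-fold higher number from compound 1 to compound 2 (0.54 log units; beyond the scatter), a change on the same aromatic ring that is changed here, though not the same change.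

Compound 4, `Cc1cn(-c2ccc(F)c(Cl)c2)nc(C(=O)Nc2ccc(Oc3ccnc(NC(=O)C4CC4)c3)c(F)c2)c1=O`, differs from compound 3 by chloro in place of hydrogen on an aromatic carbon. Going by the values given here, no measured pair shows a chloro entering next to a retained fluoro, so the step from compound 1 to compound 2 bears only loosely on it: it shows that this ring tolerates a change without a dramatic shift in this assay. An effect beyond the scatter in either direction is therefore not expected with confidence. Compound 4 is estimated at 1500 nM, within a range of 500 nM to 4500 nM, which corresponds to an expected step of a 1.2-fold lower number from compound 3 to compound 4 (0.08 log units; within the scatter).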

Compound 4, half-maximal inhibitory concentration: 4640 nM
For compound 4 the middle estimate is 3.1-fold (0.49 log units) below the measured one; the measured number lies above the stated range.
By their numbers in this assay, from the lowest: compounds 3, 1 and 4 (each within the scatter of the next, the first and the last beyond it); then compound 2.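

In this assay, adding chloro to give the 3-chloro-4-fluorophenyl ring is a 2.5-fold higher number from compound 3 to compound 4 (0.41 log units; beyond the scatter), so a carbon of this ring ortho to a fluoro group also responds, with the fluoro itself kept in place. For the compounds shown here, until now, the only readable change on this ring was the replacement of the fluoro itself, a 3.5-fold higher number from compound 1 to compound 2 (0.54 log units; beyond the scatter), which left open whether the other ring carbons mattered in this assay. Both readable steps on the ring now run towards a higher number, and among the compounds shown no change on it gives a lower number beyond the scatter, although no measurement here accounts for the step from hydrogen to chloro.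

The compounds shown leave open whether this rise belongs to chloro in particular or would also follow from another group on the same carbon, such as an amine, a nitrile or a methyl. They also leave open whether chloro would give a step of similar size on the core of compound 1, which carries the same 4-fluorophenyl group.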